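The source may report more compounds than this note shows. Statements on the series, on what has been measured and on what is new or still open speak of the compounds shown alone.

Measured so far in a functional assay on B16-F10 cells (Mus musculus) for antiproliferative activity, read by ELISA and MTT assay, with a stated time of 48 h; on this read-out higher numbers stand for weaker inhibition and lower numbers for stronger inhibition:
compound 1 `Cc1ccc(S(=O)(=O)NC(=O)/C=C/c2ccccc2)cc1` gives 13.8 ug/mL
compound 2 `O=C(/C=C/c1ccccc1[N+](=O)[O-])NS(=O)(=O)c1ccccc1` gives 6 ug/mL

Compound 2 stands at the lowest of the two numbers; its nearest neighbour is compound 1, a gap beyond the usual scatter. Compound 3 `Cc1ccc(S(=O)(=O)NC(=O)/C=C/c2ccccc2[N+](=O)[O-])cc1` has not yet been measured. It differs from compound 2 by methyl in place of hydrogen on an aromatic carbon, the aromatic carbon sitting in a six-membered aromatic ring of carbon only. Compound 1 carries the same methyl but lacks the other group that sets it apart from compound 2, so the two measured values alone cannot isolate what the methyl does. The step is expected to be a 1.1-fold higher number from compound 2 to compound 3 (0.03 log units; within the scatter), not beyond the scatter in either direction. Compound 3 is therefore estimated at 6.5 ug/mL, within 3 ug/mL to 14 ug/mL.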

Compound 3, half-maximal inhibitory concentration: 10.3 ug/mL
Beside the measured number, compound 3's estimate is 1.6-fold (0.20 log units) below it; the range from low to high includes it.
By their numbers in this assay, from the lowest: compounds 2, 3 and 1 (each within the scatter of the next, the first and the last beyond it).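

Going by these compounds alone, compound 3 gives the first single-place readings for both groups in this assay. Methyl in place of hydrogen on the aromatic carbon gives a 1.7-fold higher number from compound 2 to compound 3 (0.23 log units; within the scatter), and bringing in the nitro group gives a 1.3-fold lower number from compound 1 to compound 3 (0.13 log units; within the scatter), so neither change alone goes beyond the scatter. Nothing at hand accounts for either step.

Going by these compounds, it stays open whether an amine, a carboxylic acid or a longer chain such as ethyl in the methyl's place would step beyond the scatter. On these data alone, whether the methyl step holds without the nitro group also stays open.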